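Ester series, plasma half-life: from compound 2 to compound 3

A few compounds are considered here, and "the series" means these few. Any claim that something is new, unique, unknown or untested is made for them only; others in the source may bear on it.

In an ADME assay on a cell-free system (plasma, Homo sapiens) for metabolic stability, with Plasma (Rattus norvegicus) as the target, read by HPLC, at pH 7.4 (on this read-out higher numbers stand for a longer-lived compound and lower numbers for a shorter-lived compound), compound 1 `CCCCC(=O)O[C@@H]1CO[C@H]2[C@@H]1OC[C@@H]2OC(=O)c1ccccc1OC(C)=O` gives 0.0117 h and compound 2 `CC(=O)Oc1ccccc1C(=O)O[C@H]1CO[C@H]2[C@@H]1OC[C@H]2OC(=O)c1ccccc1C` gives 0.0138 h. Among the measured compounds shown here, on the two numbers so far, compound 2 and compound 1 sit within the scatter of each other, so neither stands apart. Compound 3 `CC(=O)Oc1ccccc1C(=O)O[C@H]1CO[C@H]2[C@@H]1OC[C@H]2OC(=O)c1ccc(-c2ccccc2)cc1` has not yet been measured in this assay; it differs from compound 2 by 4-phenylphenyl in place of 2-methylphenyl on a carbonyl carbon. For the measured compounds named here, the only measured step that bears on this change is a 1.2-fold higher number from compound 1 to compound 2 (0.07 log units; within the scatter), in which butyl gave way to 2-methylphenyl on the same carbonyl carbon. Going by the values given here, with the one exchange made so far at that carbonyl carbon having moved the half-life within the scatter only, no step beyond the scatter is expected for compound 3 in this assay, with a 1.0-fold higher number from compound 2 to compound 3 (0.01 log units; within the scatter). Compound 3 is therefore estimated at 0.014 h, with a range from 0.006 h to 0.035 h.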

Compound 3, half-life: > 0.333 h
Compound 3: no number, only a limit; the forecaster's own chance of this, stated with the estimate: 5%; at least 23-fold (1.37 log units) between middle value and limit.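

For compound 3, the reading in this assay is a limit and not a number: the limit of > 0.333 h in this assay, at which 1 of the 3 values shown sits.

This carbonyl carbon is not indifferent to its substituent: 4-phenylphenyl gives an at least 24-fold higher number from compound 2 to compound 3 (1.38 log units; beyond the scatter), and in place of butyl it gives an at least 28-fold higher number from compound 1 to compound 3 (1.45 log units; beyond the scatter). The earlier exchange of butyl for 2-methylphenyl stayed at a 1.2-fold higher number from compound 1 to compound 2 (0.07 log units; within the scatter), so among these compounds the large step goes with 4-phenylphenyl and not with the presence of a single aromatic ring.

As far as these compounds go, the true size of both new steps remains open, since each ends at a limit. Also open, from the compounds shown here alone, is whether a plain phenyl, a longer chain, or 4-phenylphenyl carrying an amine or a carboxylic acid would behave like compound 3, so ring count and group size cannot yet be told apart.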